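Adding a Second Methoxy to the Core of Compound 1

This account rests on a few compounds, and the source may have more. Where it says the series, first, only, none or still open, it means among the compounds named here.

Measured so far:
compound 1 `COc1ccccc1-c1ccccc1O`: 2.7 ug/mL
compound 2 `Nc1ccccc1-c1ccccc1O`: 44 ug/mL
compound 3 `Nc1ccccc1-c1cccc(O)c1`: 9.2 ug/mL

In a functional assay on HT-29 cells (Homo sapiens) for cytotoxicity, read by MTT assay, with a stated time of 3 days (a higher number here means a weaker inhibitor, a lower number a stronger inhibitor), compound 1 gives 2.7 ug/mL, the lowest of the three numbers and thus the strongest inhibitor of the set. Compound 3 is nearest at 9.2 ug/mL. Compound 2 is furthest at 44 ug/mL. Among the measured compounds shown here, the one measured step that changes a single place is a 16-fold higher number from compound 1 to compound 2 (1.21 log units; beyond the scatter), a large loss of potency when the methoxy of compound 1 is replaced.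

Compound 4 `COc1ccc(-c2ccccc2O)c(OC)c1` keeps the whole of compound 1 and adds one group: methoxy in place of hydrogen on an aromatic carbon. For the measured compounds named here, no measured step bears directly on this change, since the only step known swaps the methoxy for an amino rather than adding a second methoxy next to an unchanged one. With nothing to suggest a loss or a gain, the expectation is a step of no more than the usual scatter, in no particular direction. Compound 4 is therefore estimated at 3.5 ug/mL, with a range from 1.2 ug/mL to 10 ug/mL. That estimate means an expected step of a 1.3-fold higher number from compound 1 to compound 4 (0.11 log units; within the scatter).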

Compound 4, half-maximal inhibitory concentration: 33.7 ug/mL
Estimate against measurement, compound 4: 9.6-fold (0.98 log units) below; measured number above the stated range.
By their numbers in this assay, from the lowest: compound 1; then compound 3; then compounds 4 and 2 (each within the scatter of the next).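

In this assay, adding a methoxy in place of hydrogen brings a 12-fold higher number from compound 1 to compound 4 (1.10 log units; beyond the scatter), so this position, meta to a methoxy group and para to a group of 7 heavy atoms, cannot be treated as a free place for adding to compound 1. The earlier step, a 16-fold higher number from compound 1 to compound 2 (1.21 log units; beyond the scatter), came from replacing the methoxy itself, whereas this one shows that a large loss of potency can also occur when that methoxy stays and a new group enters elsewhere on the shared core. No measurement available here explains why the added methoxy has this effect.

On these data alone, it remains open whether the loss belongs to methoxy in particular or would also follow from a fluorine atom or a methyl group at this position. Also open, as far as these compounds go, is whether a methoxy on another aromatic carbon of the core would bring a similar step.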